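One Flipped Ring Stereocentre: Compound 3 to Compound 4

A few compounds are considered here, and "the series" means these few. Any claim that something is new, unique, unknown or untested is made for them only; others in the source may bear on it.

Compound 1 `Cc1ccc(C(=O)OC2CCN(C)CC2)cc1` gives 18.2 mg/kg in a functional assay on the whole organism with Mus musculus as the target, in the hot plate test; a lower number here means that less compound is needed, a higher number that more compound is needed for the effect.
Compound 2 `COc1cc(OC)cc(C(=O)OC2CCN(C)CC2)c1` gives 9.3 mg/kg in this assay.
Compound 3 `CCOC(=O)[C@@H]1CN(C)CC[C@@H]1OC(=O)c1ccc(OC)c(OC)c1` gives 4 mg/kg in this assay.

Compound 3 has the lowest number of the three; its gap to compound 2 lies beyond the usual scatter, and its gap to compound 1 is larger still. Compound 4 `CCOC(=O)[C@H]1CN(C)CC[C@@H]1OC(=O)c1ccc(OC)c(OC)c1` is not yet tested in this assay. It differs from compound 3 in one way: the two compounds have the same atoms and bonds and differ only in configuration as drawn: 1 of 2 stereo elements differ; a stereocentre at a saturated ring carbon is drawn R in compound 3 and S in compound 4. For the measured compounds named here, no measured pair in this set shows what such a flip at a ring carbon does, so the direction stays open. The expected step of a 2.0-fold higher number from compound 3 to compound 4 (0.30 log units; within the scatter) is a moderate rise in the number, with a range wide enough to allow a fall instead. Compound 4 is estimated at 8 mg/kg, expected between 2.5 mg/kg and 30 mg/kg.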

Compound 4, dose for half-maximal effect: 11.8 mg/kg
The estimate for compound 4 lay 1.5-fold (0.17 log units) below the measured number; the measured number falls inside the stated range.
By their numbers in this assay, from the lowest: compound 3; then compounds 2, 4 and 1 (each within the scatter of the next).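

Turning this one saturated ring carbon from R to S gives a 3.0-fold higher number from compound 3 to compound 4 (0.47 log units; beyond the scatter) in this assay. This step can be assigned to the spatial arrangement alone, because nothing else changes: the fact that compounds 3 and 4 differ only in the configuration as drawn

For the compounds shown here, none of the earlier compounds formed such a pair, so this is the first sign that the dose needed here depends on configuration at this ring carbon, not only on which groups are present.

From the compounds shown here alone, what a flip at the other stereocentre would do stays open. So does whether this flip would give a similar step if a carboxylic acid or an amide replaced the ethyl ester.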